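The source may hold more compounds than are shown below. What is called first, only, known or untested is meant among the compounds shown, and "the series" means these compounds.

Two compounds of this series carry a number in an assay on isolated protein for inhibition of 15-hydroxyprostaglandin dehydrogenase [NAD(+)] (Homo sapiens), read by fluorescence, with a stated time of 15 min; on this read-out higher numbers stand for weaker inhibition and lower numbers for stronger inhibition. Compound 1, `Cc1cc(-c2nnc3n2CCCCC3)c(C)n1-c1cccc2ccccc12`, gives 108 nM. Compound 2, `Cc1cccc(-n2cnc3cc(C(=O)N4CC(C)CC(C)C4)ccc32)c1`, gives 271 nM, the higher of the two numbers; the gap to compound 1 lies beyond the scatter, so compound 2 is the weaker inhibitor of the pair. For the measured compounds named here, the two compounds share no common core, and no measured pair differs in a single place, so nothing is yet known about the effect of one change within one scaffold.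

Compound 3, `Cc1cccc(-n2cnc3cc(C(=O)N4CCC(Br)CC4)ccc32)c1`, keeps all of compound 2 apart from the amide substituent: 4-bromopiperidin-1-yl in place of 3,5-dimethylpiperidin-1-yl on a carbonyl carbon. In both compounds the amide nitrogen sits in a six-membered non-aromatic ring, and neither group brings a hydrogen-bond donor or acceptor. Going by the values given here, no measured pair tests a change of this kind, so there is no step to lean on. The expected step in this assay is a 1.2-fold higher number from compound 2 to compound 3 (0.07 log units; within the scatter), held close to the scatter with no firm direction. Compound 3 is therefore expected to give 320 nM in this assay, with a likely range from 120 nM to 850 nM.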

Compound 3, half-maximal inhibitory concentration: 76 nM
Compound 3: the middle estimate sits 4.2-fold (0.62 log units) above what was measured, and the stated range ends above it.
By their numbers in this assay, from the lowest: compounds 3 and 1 (each within the scatter of the next); then compound 2.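

In this assay, for the compounds shown here, the amide substituent on the carbonyl carbon turns out to be a place where the number moves: 4-bromopiperidin-1-yl in place of 3,5-dimethylpiperidin-1-yl gives a 3.6-fold lower number from compound 2 to compound 3 (0.55 log units; beyond the scatter) and provides the first single-place step. The size of this step stands out against what the two groups have in common, since each has one six-membered non-aromatic ring with 1 hetero atom, 0 hydrogen-bond donors, 0 hydrogen-bond acceptors and no net charge, so these shared counts alone do not fix the number at this position. No measurement at hand accounts for the step.

This single pair does not separate the departure of the two methyl groups from the arrival of the bromine, and it cannot tell whether the same exchange would carry over to the core of compound 1. Piperidin-1-yl without a substituent, 4-chloropiperidin-1-yl or morpholin-4-yl on the same carbonyl carbon would show how much of the step belongs to the bromine itself.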